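The compounds below may be only part of what the source reports. "The series", "measured", "known", "first", "only" and "open" are said of these compounds alone.

Measured in a functional assay on MCF7 cells (Homo sapiens) for cytotoxicity, read by MTT assay, with a stated time of 72 h; a higher number here means a weaker inhibitor, a lower number a stronger inhibitor:
- Compound 1 `CC(C)=C1C(=O)N(c2ccc(Cl)cc2)N(c2ccc(Cl)cc2)C1=O`: 39600 nM
- Compound 2 `O=C1C(=Cc2cccc(Cl)c2)C(=O)N(c2ccc(Cl)cc2)N1c1ccc(Cl)cc1`: 18300 nM

Compound 2, at 18300 nM, has the lower of the two numbers, which makes it the stronger inhibitor of this pair, and its gap to compound 1 lies beyond the usual scatter. The two compounds differ in more than one place, so that gap does not isolate the effect of any single group.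

Compound 3 `O=C1C(=Cc2ccco2)C(=O)N(c2ccc(Cl)cc2)N1c1ccc(Cl)cc1` keeps the rest of compound 2 but has furan-2-yl in place of 3-chlorophenyl on a double-bonded chain carbon bound to a double-bonded ring carbon. Within the data shown here, no measured pair shows this swap, so there is no direct precedent for its size. In this assay, no step beyond the scatter is therefore expected, with a slight lean towards a higher number. The estimated step is a 1.2-fold higher number from compound 2 to compound 3 (0.08 log units; within the scatter). For compound 3 the estimated value is 22000 nM, with an expected range of 8000 nM to 60000 nM.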

Compound 3, half-maximal inhibitory concentration: 20300 nM
Compound 3: middle estimate off by 1.1-fold (0.03 log units), on the high side; low and high end bracket the measured number.
By their numbers in this assay, from the lowest: compounds 2, 3 and 1 (each within the scatter of the next, the first and the last beyond it).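

In this assay, furan-2-yl in place of 3-chlorophenyl on a double-bonded chain carbon bound to a double-bonded ring carbon gives a 1.1-fold higher number from compound 2 to compound 3 (0.05 log units; within the scatter). This position therefore takes a five-membered aromatic ring with one oxygen as well as a six-membered all-carbon ring bearing chlorine, with no difference that can be told from the scatter. Nothing measured here explains why the two rings give such similar numbers. 

Both groups at this position are aromatic rings, so the compounds shown leave open whether a non-aromatic group, such as an amine, a carboxylic acid or a longer chain, would shift the number beyond the scatter. They also leave open whether any change here could bring cytotoxicity well beyond that of compound 2.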